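The compounds below may be only part of what the source reports. "The series", "measured", "known", "first", "only" and "open" are said of these compounds alone.

Measured compounds:
Compound 1, `COc1ccccc1N1CCN(CC(=O)N2CCN(c3nnc(-c4ccccc4)c(-c4ccccc4)n3)CC2)CC1`: 167000 nM
Compound 2, `O=C(CN1CCN(c2ccccc2Cl)CC1)N1CCN(c2nnc(-c3ccccc3)c(-c3ccccc3)n2)CC1`: 263000 nM

Compound 2 gives the highest of the two numbers in a functional assay on MCF7 cells (Homo sapiens) for cytotoxicity, read by MTT assay, with a stated time of 24 h; a lower number here means a stronger inhibitor, a higher number a weaker inhibitor; its nearest neighbour is compound 1, and the difference a 1.6-fold higher number from compound 1 to compound 2 (0.20 log units; within the scatter) stays within the scatter, so neither stands apart from the other. Compound 3, `COc1cccc(N2CCN(CC(=O)N3CCN(c4nnc(-c5ccccc5)c(-c5ccccc5)n4)CC3)CC2)c1`, has not yet been tested. It differs from compound 2 by 3-methoxyphenyl in place of 2-chlorophenyl on an amine nitrogen in a ring. For the measured compounds named here, only one measured step bears on this change: a 1.6-fold higher number from compound 1 to compound 2 (0.20 log units; within the scatter), where chloro replaced methoxy on the aromatic ring without a shift beyond the scatter. Going by the values given here, compound 3 carries a methoxy group again, now on a different carbon of that ring, a move for which no measured pair exists. The step of a 1.5-fold lower number from compound 2 to compound 3 (0.16 log units; within the scatter) is therefore expected to stay within the scatter. Compound 3 is estimated at 180000 nM, with a range from 80000 nM to 400000 nM.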

Compound 3, half-maximal inhibitory concentration: > 910000 nM
Compound 3 was reported as a limit; the forecaster's own chance of this, stated with the estimate: 15%; at least 5.0-fold (0.70 log units) between middle value and limit.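

Compound 3 is reported in this assay only as a limit, not as a number: the limit of > 910000 nM in this assay, at which 1 of the 3 values shown sits. Compound 1 and compound 3 carry the same kind of group on the amine nitrogen, 2-methoxyphenyl and 3-methoxyphenyl, and this change alone gives an at least 5.4-fold higher number from compound 1 to compound 3 (0.73 log units; beyond the scatter). The change from 2-chlorophenyl gives an at least 3.4-fold higher number from compound 2 to compound 3 (0.53 log units; beyond the scatter), whereas exchanging chloro for methoxy on the same ring carbon gave only a 1.6-fold higher number from compound 1 to compound 2 (0.20 log units; within the scatter), so among these three compounds where the methoxy sits counts for more than which of the two groups is present.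

Going by these compounds, how far the true value of compound 3 lies past its limit remains open. So does whether 3-chlorophenyl, 4-methoxyphenyl or a plain phenyl on that amine nitrogen would follow compound 3 or stay with compound 1 and compound 2.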